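The source may report more compounds than this note shows. Statements on the series, on what has been measured and on what is new or still open speak of the compounds shown alone.

Compound 1 has the structure `CS(=O)(=O)c1nc(N)c2ccn(COCCO)c2n1`. In a functional assay on BSC-1 cells (Cercopithecidae) for cytotoxicity (a lower number here means a stronger inhibitor, a higher number a weaker inhibitor), compound 1 gives > 100000 nM, which is a limit of the assay and not a number.
Compound 2 has the structure `COc1nc(N)c2ccn(COCCO)c2n1`. In this assay compound 2 gives > 100000 nM, again a limit of the assay.
Compound 3 has the structure `CC(=O)Nc1nc(Cl)c2ccn(COCCO)c2n1`. In this assay compound 3 gives > 100000 nM, also a limit of the assay.

Compound 2 thus stands at the limit, and so do the two other measured compounds; all three sit at the limit of > 100000 nM in this assay, at which 3 of the 3 values shown sit. Among the compounds with values here, the only measured step that changes one place, a step that the two limits leave unreadable from compound 1 to compound 2, runs between two limits and is therefore of unreadable size. Compound 4, with the structure `Nc1nc(N)c2ccn(COCCO)c2n1`, differs from compound 2 by amino in place of methoxy on an aromatic carbon. Within the data shown here, both this new change and the one measured step replace a small group on the same position of the shared core, and that measured step gave nothing readable, so no step beyond the scatter can be expected in this assay from compound 2 to compound 4; the estimated step is a step that the limit leaves unreadable from compound 2 to compound 4. Compound 4 is therefore expected to give about 200000 nM in this assay, with a range from 50000 nM to 1000000 nM, most likely reported only as a limit.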

Compound 4, half-maximal inhibitory concentration: > 100000 nM
Compound 4: only a limit was reported; the forecaster's own chance of this, stated with the estimate: 85%; the middle value is on the limit's open side.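

No step among compound 1, compound 2 and compound 4 can be read in this assay, since each result is a limit of the assay and not a number: the limit of > 100000 nM in this assay, at which 4 of the 4 values shown sit.

The compounds shown leave open whether methylsulfonyl, methoxy and amino on the shared core differ at all in this assay; none of the three gives a readable number.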